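A few compounds are considered here, and "the series" means these few. Any claim that something is new, unique, unknown or untested is made for them only; others in the source may bear on it.

Three compounds share one core and differ only in the group on one aromatic carbon. Compound 1 `COc1cccc2c1nc(-c1c(F)cccc1F)n2Cc1c(F)cccc1F` carries a methoxy there; in a toxicity assay on CCRF-CEM cells (Homo sapiens) for cytotoxicity (a higher number here means that more compound is tolerated, a lower number that less compound is tolerated), compound 1 gives 44.3 uM. Compound 2 `CCc1cccc2c1nc(-c1c(F)cccc1F)n2Cc1c(F)cccc1F` carries an ethyl instead, and in this assay compound 2 gives 26.1 uM. Compound 3 `CC(C)c1cccc2c1nc(-c1c(F)cccc1F)n2Cc1c(F)cccc1F` carries an isopropyl, and in this assay compound 3 gives 27 uM. Compound 1 stands at the top of these three numbers, yet the steps of a 1.7-fold lower number from compound 1 to compound 2 (0.23 log units; within the scatter) and a 1.6-fold lower number from compound 1 to compound 3 (0.22 log units; within the scatter) both fall within the scatter, as does a 1.0-fold higher number from compound 2 to compound 3 (0.01 log units; within the scatter). Compound 4 `[N-]=[N+]=NCc1cccc2c1nc(-c1c(F)cccc1F)n2Cc1c(F)cccc1F` has not been measured. azidomethyl in place of methoxy on an aromatic carbon The two measured steps that start from compound 1 bear on this change: each also swaps the methoxy for another group at that carbon, and neither moved the number beyond the scatter. A similar outcome is therefore expected for compound 4, with a 1.3-fold lower number from compound 1 to compound 4 (0.13 log units; within the scatter) as the expected step. For compound 4 in this assay the estimate is 33 uM, in a range from 14 uM to 75 uM.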

Compound 4, half-maximal toxic concentration: > 100 uM
Compound 4 gave a limit, no number (the forecaster's own chance of this, stated with the estimate: 5%); middle value at least 3.0-fold (0.48 log units) away from the limit.
By their numbers in this assay, from the lowest: compounds 2, 3 and 1 (each within the scatter of the next). At a limit, above all of these: compound 4.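

In this assay, compound 4 gives a limit and not a number: the limit of > 100 uM in this assay, at which 1 of the 4 values shown sits. This position is therefore not indifferent to what sits on it: methoxy, ethyl and isopropyl gave values within the scatter of one another, whereas azidomethyl gives an at least 2.2-fold higher number from compound 1 to compound 4 (0.35 log units; beyond the scatter), an at least 3.7-fold higher number from compound 3 to compound 4 (0.56 log units; beyond the scatter) and an at least 3.8-fold higher number from compound 2 to compound 4 (0.58 log units; beyond the scatter). So among the four groups shown, only the change to azidomethyl moves the number beyond the scatter, and it moves it towards more compound being tolerated.

Going by these compounds, all three steps are minimum sizes, so the full size of the change stays open. On these data alone, whether the azide end of the group matters, or any group of this length would do the same, stays open too; an aminomethyl or a longer chain such as butyl on this aromatic carbon would help to tell these apart.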